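The source may report more compounds than this note shows. Statements on the series, on what has been measured and on what is new or still open speak of the compounds shown alone.

Measured so far:
compound 1, `CCC(C)C1NC(=O)N(C2CCCCC2)C1=O` — 69700 nM
compound 2, `CCC(C)C(NC(=O)NO)C(=O)NC(c1ccccc1)c1ccccc1` — 35800 nM

In a functional assay on HEp-2 cells (Homo sapiens) for inhibition (on this read-out higher numbers stand for weaker inhibition and lower numbers for stronger inhibition), compound 2 gives 35800 nM, the lowest of the two numbers; compound 1 stands near it, and the gap between the two lies within the scatter, so neither is set apart from the other.

Compound 3, `CCC(C)C(NC(=O)n1nnc2ccccc21)C(=O)NC(c1ccccc1)c1ccccc1`, is compound 2 with one change: a group of 9 heavy atoms (6 carbon, 3 nitrogen; one five-membered aromatic ring with 3 hetero atoms, one six-membered aromatic ring of carbon only) in place of a group of 2 heavy atoms (1 nitrogen, 1 oxygen; no ring), on a carbonyl carbon. Within the data shown here, no step between measured compounds covers a change of this kind, so the expectation rests on compound 2 alone. A step of modest size toward a higher number is expected in this assay, though nothing beyond the scatter would also be unsurprising. For compound 3 the estimate in this assay is 55000 nM, range 12000 nM to 250000 nM, which means an expected step of a 1.5-fold higher number from compound 2 to compound 3 (0.19 log units; within the scatter).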

Compound 3, half-maximal inhibitory concentration: 55300 nM
Estimate against measurement, compound 3: 1.0-fold (0.00 log units) below, within the range that was stated.
By their numbers in this assay, from the lowest: compounds 2, 3 and 1 (each within the scatter of the next).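

In this assay, exchanging hydroxyamino for the group with a five-membered and a six-membered aromatic ring, on the carbonyl carbon, gives a 1.5-fold higher number from compound 2 to compound 3 (0.19 log units; within the scatter) and does not set the two compounds apart. The hydroxyamino group and its hydrogen-bond donors are therefore not needed here to keep a number at this level, as the entering group has no hydrogen-bond donors. No measurement is at hand that accounts for this result.

From the compounds shown here alone, whether an amine, a carboxylic acid or a methyl group on this carbonyl carbon would give a number beyond the scatter from compound 2 stays open. Also open, going by these compounds, is whether any group at this place gives a clearly lower number.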